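Taking One Methoxy Off an Ester at Its Limit

The source may hold more compounds than are shown below. What is called first, only, known or untested is meant among the compounds shown, and "the series" means these compounds.

Three esters have been tested in a functional assay on the whole organism (strain Kunming) with Mus musculus as the target, with a stated time of 0.5 h; on this read-out higher numbers stand for an effect only at larger amounts of compound and lower numbers for an effect already at smaller amounts. Compound 1 `COc1ccccc1/C=C/C(=O)OC/C=C/c1cc(OC)c(OC)cc1OC` gives only a limit, > 300 mg/kg. Compound 2 `COc1cc(OC)c(OC)cc1/C=C/COC(=O)/C=C/c1ccc(OC)c(OC)c1` also gives only a limit, > 300 mg/kg. Compound 3 `COc1cc(OC)c(OC)cc1/C=C/COC(=O)/C=C/c1cc(OC)c(OC)c(OC)c1OC` stands at a limit too, > 200 mg/kg, so it has no exact number. Compound 4 `COc1cc(OC)c(OC)cc1/C=C/COC(=O)/C=C/c1cc(OC)c(OC)c(OC)c1` differs from compound 3 by one change: hydrogen in place of methoxy on an aromatic carbon. Among the compounds with values here, the one measured step that bears on this is a step that the two limits leave unreadable from compound 1 to compound 2, which also alters the methoxy groups on that ring but gives no size to carry over. I therefore expect no clear step in either direction in this assay, and another limit is likely. The expected change is a step that the limit leaves unreadable from compound 3 to compound 4. For compound 4 the estimated value is 300 mg/kg, with an expected range from 120 mg/kg to 600 mg/kg.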

Compound 4, dose for half-maximal effect: > 200 mg/kg
Compound 4 gave a limit, no number (the forecaster's own chance of this, stated with the estimate: 75%); the middle value does not contradict the limit.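

Within the data shown here, compound 2, compound 3 and compound 4 all give only limits, not numbers, so no step between them can be read. The compounds shown leave open whether hydrogen in place of methoxy changes the dose in this assay at all.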